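This account rests on a few compounds, and the source may have more. Where it says the series, first, only, none or still open, it means among the compounds named here.

Measured so far in an assay on isolated protein (Cavia porcellus) with cysteinyl leukotriene receptor (Homo sapiens) as the target; on this read-out lower numbers stand for lower potency and higher numbers for higher potency (the scale is a negative logarithm):

- compound 1, `COc1cc(C(=O)NS(=O)(=O)c2ccccc2)ccc1Cc1cn(C)c2ccc(NC(=O)OC3CCCC3)cc12`: 9.69
- compound 2, `CCCn1cc(Cc2ccc(C(=O)O)cc2OC)c2cc(NC(=O)OC3CCCC3)ccc21`: 7.72
- compound 3, `CCCn1cc(Cc2ccc(C(=O)NS(=O)(=O)c3ccccc3)cc2OC)c2cc(NC(=O)OC3CCCC3)ccc21`: 8.44

Compound 2 gives the lowest of the three numbers in this assay. Two single-point changes connect the set. From compound 2 to compound 3 the carbonyl carbon carries the change hydroxy in place of (phenylsulfonyl)amino on a carbonyl carbon read in reverse, and the step is a number 0.72 log units higher from compound 2 to compound 3 (beyond the scatter). From compound 3 to compound 1 the change is hydrogen in place of ethyl on a saturated chain carbon bound to an aromatic nitrogen, and the step is a number 1.25 log units higher from compound 3 to compound 1 (beyond the scatter).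

Compound 4, `COc1cc(C(=O)O)ccc1Cc1cn(C)c2ccc(NC(=O)OC3CCCC3)cc12`, has not yet been measured in this assay. It differs from compound 2 by hydrogen in place of ethyl on a saturated chain carbon bound to an aromatic nitrogen, the same change as that between compound 3 and compound 1, at a place described in identical words. Within the data shown here, the two cores on which the change is made differ by hydroxy in place of (phenylsulfonyl)amino on a carbonyl carbon, so the only precedent for this change sits on the other core.

For compound 4 the step is expected to be a number 1.08 log units higher from compound 2 to compound 4 (beyond the scatter). Among the measured compounds shown here, that expectation rests on the single earlier instance, a number 1.25 log units higher from compound 3 to compound 1 (beyond the scatter), tempered because only one example exists. Compound 4 is therefore estimated at 8.8, with a range from 8.1 to 9.5.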

Compound 4, negative logarithm of the antagonist equilibrium constant: 7.84
For compound 4 the middle estimate is 0.96 log units above the measured one; measured number below the stated range.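

In this assay, the propyl to methyl change on the core carrying hydroxy on the carbonyl carbon gives a number 0.12 log units higher from compound 2 to compound 4 (within the scatter), so the rise seen on the core carrying (phenylsulfonyl)amino does not carry over: the same change on two cores in this assay, a number 1.25 log units higher (beyond the scatter) from compound 3 to compound 1 and a number 0.12 log units higher (within the scatter) from compound 2 to compound 4, 1.13 log units apart, beyond the scatter of two such steps

The change to hydroxy from (phenylsulfonyl)amino on a carbonyl carbon, read on the methyl core, gives a number 1.85 log units lower from compound 1 to compound 4 (beyond the scatter), and its size also differs with the core: the same change on two cores in this assay, a number 0.72 log units higher (beyond the scatter) from compound 2 to compound 3 and a number 1.85 log units higher (beyond the scatter) from compound 4 to compound 1, 1.13 log units apart, beyond the scatter of two such steps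

Across these four compounds the two changes therefore do not add independently, and a step measured on one core does not set its size on the other, but with one pair per core this shows neither why the steps differ nor how general the dependence is.

As far as these compounds go, whether an ethyl or butyl chain in place of the methyl or propyl would follow the same dependence remains open. From the compounds shown here alone, it is also open whether (methylsulfonyl)amino on the carbonyl carbon would behave like (phenylsulfonyl)amino or like hydroxy when the chain changes.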